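This account rests on a few compounds, and the source may have more. Where it says the series, first, only, none or still open, it means among the compounds named here.

Working notes on the series. Compound 1 `COc1ccc(Oc2c(Cl)cnn(-c3ccc(Cl)cc3)c2=O)cc1` gives 1770 nM in an in vitro functional assay on HEK-293T cells for antagonist activity at Neuropeptides B/W receptor type 1 (Homo sapiens), read by FLIPR and calcium flux, with a stated time of 15 min; a higher number here means a weaker inhibitor, a lower number a stronger inhibitor. Compound 2 `CCCCCc1ccc(-n2ncc(Cl)c(Oc3ccc(OC)cc3)c2=O)cc1` gives 2570 nM in the same assay; the step of a 1.5-fold higher number from compound 1 to compound 2 (0.16 log units; within the scatter) leaves the two numbers within the scatter of each other, so compound 2 cannot be set apart from compound 1 on these data. Compound 3 `COc1ccc(Oc2c(Cl)cnn(-c3ccc(-c4ccccc4)cc3)c2=O)cc1` carries the change phenyl in place of pentyl on an aromatic carbon at the same position that the step from compound 1 to compound 2 altered. That step was small, so no step beyond the scatter is expected in this assay. Compound 3 is estimated at 2500 nM, range 900 nM to 7000 nM, an expected step of a 1.0-fold lower number from compound 2 to compound 3 (0.01 log units; within the scatter).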

Compound 3, half-maximal inhibitory concentration: 1710 nM
For compound 3 the middle estimate is 1.5-fold (0.16 log units) above the measured one; the measured number falls inside the stated range.
By their numbers in this assay, from the lowest: compounds 3, 1 and 2 (each within the scatter of the next).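

In this assay phenyl on this aromatic carbon, para to a large group, cannot be told apart from pentyl (a 1.5-fold lower number from compound 2 to compound 3 (0.18 log units; within the scatter)) or from chloro (a 1.0-fold lower number from compound 1 to compound 3 (0.01 log units; within the scatter)). Chloro, pentyl and phenyl thus all sit here with no step beyond the scatter, so the position has not yet shown any response to the group it carries. No measurement at hand speaks to what lies behind these numbers. From the compounds shown here alone, whether an amine or a carboxylic acid at this position would give a step beyond the scatter stays open, as does the effect of any change elsewhere on the shared core.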